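Methoxy to cyclopropyl on the shared core

The source may report more compounds than this note shows. Statements on the series, on what has been measured and on what is new or still open speak of the compounds shown alone.

Of the compounds shown here, three have been measured in an ADME assay on LLC-PK1 cells (Sus scrofa) for permeability, read by LC-MS, with a stated time of 2 h, tested at 5 uM; a lower number here means that the compound crosses the layer more slowly, a higher number that the compound crosses the layer faster. Compound 1 (`CC#Cc1cncc(-c2ccc3c(c2)[C@@]2(COC(N)=N2)c2cc(-c4ccnc(F)c4)ncc2O3)c1`) gives 15 nm/s, compound 2 (`Cc1cc2c(cn1)Oc1ccc(NC(=O)c3ccc(Cl)cn3)cc1[C@@]21COC(N)=N1`) gives 40 nm/s and compound 3 (`COc1cc2c(cn1)Oc1ccc(NC(=O)c3ccc(Cl)cn3)cc1[C@@]21COC(N)=N1`) gives 25 nm/s. Compound 3 therefore lies within the scatter of both other compounds, and its number offers no clear separation from either.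

Compound 4 (`NC1=N[C@@]2(CO1)c1cc(NC(=O)c3ccc(Cl)cn3)ccc1Oc1cnc(C3CC3)cc12`) carries cyclopropyl in place of methoxy on an aromatic carbon, next to the ring nitrogen: cyclopropyl in place of methoxy on an aromatic carbon. Among the compounds with values here, no measured compound carries cyclopropyl, so the data give no direct reading of this group. Within the data shown here, one measured step bears on the change, because it exchanges groups on the same aromatic carbon: a 1.6-fold lower number from compound 2 to compound 3 (0.20 log units; within the scatter). That step stayed within the scatter, so no step beyond the scatter is expected in this assay here, and no firm direction can be assigned.

The estimated step is a 1.2-fold higher number from compound 3 to compound 4 (0.08 log units; within the scatter), which is expected to remain within the scatter. For compound 4 the estimated value is 30 nm/s. The expected range runs from 13 nm/s to 65 nm/s.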

Compound 4, apparent permeability: 29 nm/s
For compound 4 the middle estimate is 1.0-fold (0.01 log units) above the measured one; low and high end bracket the measured number.
By their numbers in this assay, from the lowest: compounds 1, 3, 4 and 2 (each within the scatter of the next, the first and the last beyond it).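

In this assay the step of a 1.2-fold higher number from compound 3 to compound 4 (0.06 log units; within the scatter) shows that this aromatic carbon also tolerates a group with a three-membered carbon ring and no hydrogen-bond acceptor, with the number staying within the scatter. Within the data shown here, the step of a 1.4-fold lower number from compound 2 to compound 4 (0.14 log units; within the scatter) extends this to the methyl compound, so methyl, methoxy and cyclopropyl on this carbon now form a set with no separation among them, where the earlier compounds offered only one pair. Nothing measured here explains this lack of separation.

Whether any group at this carbon can move the number beyond the scatter remains open, since an amine, a carboxylic acid or a longer alkyl chain does not appear among these compounds. Compound 1 differs from the others in more than one place, so it cannot settle this question.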